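Trifluoromethyl ketone series: carbamate ester swap

The source may report more compounds than this note shows. Statements on the series, on what has been measured and on what is new or still open speak of the compounds shown alone.

Of the compounds shown here, three carrying a trifluoromethyl ketone have been measured in a functional assay (Homo sapiens) for cytotoxicity; a lower number here means that less compound is tolerated, a higher number that more compound is tolerated. Compound 1 `O=C(c1ccccc1)C(O)C(F)(F)F` gives 240000 nM. Compound 2 `O=C(NCCCC(=O)C(O)C(F)(F)F)c1ccccc1` gives 400000 nM. Compound 3 `O=C(Oc1ccccc1)N1C=C(C(=O)C(F)(F)F)CC1` gives 270000 nM; this is the second highest of the three numbers, with compound 1 nearest and compound 2 furthest, both within the scatter, so no order among the three can be claimed. Compound 4 `C=CCOC(=O)N1C=C(C(=O)C(F)(F)F)CC1` is the next step from compound 3: allyl in place of phenyl on an oxygen next to a carbonyl group. Among the compounds with values here, no step between measured compounds is available for comparison, and the three measured numbers lie close together. In this assay the expected step is none beyond the scatter, the estimated move being a 1.1-fold higher number from compound 3 to compound 4 (0.05 log units; within the scatter). Compound 4 is accordingly expected at 300000 nM, within a range from 120000 nM to 700000 nM.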

Compound 4, half-maximal cytotoxic concentration: 240000 nM
Estimate against measurement, compound 4: 1.3-fold (0.10 log units) above; the range from low to high includes it.
By their numbers in this assay, from the lowest: compounds 1, 4, 3 and 2 (each within the scatter of the next).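

On an oxygen next to a carbonyl group, allyl in place of phenyl gives a 1.1-fold lower number from compound 3 to compound 4 (0.05 log units; within the scatter) in this assay. Within the data shown here, this is the first single-place step, and it shows that this position accepts loss of the aromatic ring without a move beyond the scatter. No measured property bears on this result.

Still open, as far as these compounds go, is whether a longer chain in place of allyl, or an amine or a carboxylic acid at this position, would shift the number beyond the scatter.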